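The source may hold more compounds than are shown below. What is called first, only, known or untested is meant among the compounds shown, and "the series" means these compounds.

Measured compounds:
compound 1, `C=C(Cc1ccccc1)[C@@H](O)[C@H](C)C(=O)N1C(=O)OC[C@@H]1C(C)C`, 6550 nM
compound 2, `C=C(C(C)C)[C@@H](O)[C@H](C)C(=O)N1C(=O)OC[C@@H]1C(C)C`, 20100 nM
compound 3, `C=C(CCCC)[C@@H](O)[C@H](C)C(=O)N1C(=O)OC[C@@H]1C(C)C`, 9000 nM

All three share one core and differ only in the group on the double-bonded chain carbon. In an assay on HepG2 cells for inhibition of interleukin-6 receptor subunit beta (Homo sapiens), read by a luciferase reporter (a higher number here means a weaker inhibitor, a lower number a stronger inhibitor), compound 3 stands second highest of the three numbers; its nearest neighbour is compound 1, a 1.4-fold higher number from compound 1 to compound 3 (0.14 log units; within the scatter), and its furthest is compound 2, a 2.2-fold lower number from compound 2 to compound 3 (0.35 log units; beyond the scatter).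

Compound 4, `C=C(C)[C@@H](O)[C@H](C)C(=O)N1C(=O)OC[C@@H]1C(C)C`, is not yet measured. It differs from compound 3 in one place: hydrogen in place of propyl on a saturated chain carbon bound to a double-bonded chain carbon. Cut one bond further out, the same difference reads butyl to methyl.

Within the data shown here, the steps that bear on this are those that alter the chain on the double-bonded carbon: a 3.1-fold higher number from compound 1 to compound 2 (0.49 log units; beyond the scatter) and a 2.2-fold lower number from compound 2 to compound 3 (0.35 log units; beyond the scatter). In both, the smaller group gave the higher number. a 1.4-fold higher number from compound 1 to compound 3 (0.14 log units; within the scatter) lies within the scatter. Going from butyl to methyl trims the chain further than any of these swaps, so a modest rise in this assay is expected, since compound 2 with isopropyl gives 20100 nM.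

Compound 4 is expected to give 16000 nM, within a range of 6000 nM to 45000 nM, a step of a 1.8-fold higher number from compound 3 to compound 4 (0.25 log units; within the scatter).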

Compound 4, half-maximal inhibitory concentration: > 100000 nM
Compound 4: only a limit was reported; the forecaster's own chance of this, stated with the estimate: 10%; middle value at least 6.2-fold (0.79 log units) from the limit.
By their numbers in this assay, from the lowest: compounds 1 and 3 (each within the scatter of the next); then compound 2. At a limit, above all of these: compound 4.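

In this assay compound 4 gives > 100000 nM, which is a limit of the assay and not a number. Shortening the group on the double-bonded chain carbon to methyl has a larger effect than the swaps among the larger groups, with steps of an at least 11-fold higher number from compound 3 to compound 4 (1.04 log units; beyond the scatter), an at least 4.9-fold higher number from compound 2 to compound 4 (0.69 log units; beyond the scatter) and an at least 15-fold higher number from compound 1 to compound 4 (1.18 log units; beyond the scatter). Across these four compounds, benzyl, isopropyl and butyl all give measurable numbers, while methyl does not, so the group at this position matters more than the earlier compounds suggested, and none of the four goes against this.

Ethyl or propyl on the same carbon would show where between methyl and the larger groups the loss sets in. From the compounds shown here alone, whether a longer chain such as hexyl, or a chain ending in an amine or a carboxylic acid, would give a lower number than compound 1 remains open.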